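The source may report more compounds than this note shows. Statements on the series, on what has been measured and on what is new or still open speak of the compounds shown alone.

Series notes, read-out in a functional assay on BaF3 cells (Mus musculus) for antiproliferative activity; on this read-out higher numbers stand for an effect only at larger amounts of compound and lower numbers for an effect already at smaller amounts:

- compound 1 `CCN1CCN(Cc2ccc(NC(=O)c3ccc(C)c(C#Cc4ccc(NC(C)=O)nc4)c3)cc2C(F)(F)F)CC1`: 2050 nM
- compound 2 `CCN1CCN(Cc2ccc(NC(=O)c3ccc(C)c(C#Cc4cnc5[nH]c(C)cc5c4)c3)cc2C(F)(F)F)CC1`: 1000 nM
- compound 3 `CCN1CCN(Cc2ccc(NC(=O)c3ccc(C)c(C#Cc4coc5ccccc45)c3)cc2C(F)(F)F)CC1`: not yet measured

For the measured compounds named here, of the two numbers available, compound 2 has the lower, at 1000 nM, and compound 1 is its only neighbour. The next change is a group of 9 heavy atoms (8 carbon, 1 oxygen; one five-membered aromatic ring with 1 hetero atom, one six-membered aromatic ring of carbon only) in place of a group of 10 heavy atoms (8 carbon, 2 nitrogen; one five-membered aromatic ring with 1 hetero atom, one six-membered aromatic ring with 1 hetero atom), on a triple-bonded carbon. Here 1-benzofuran-3-yl enters on the same triple-bonded carbon, and the shared core stays untouched.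

Going by the values given here, only one measured step bears on this: a 2.1-fold lower number from compound 1 to compound 2 (0.31 log units; beyond the scatter). It is modest and was made at this same place, but with a different incoming group. Among the compounds with values here, no measured compound carries 1-benzofuran-3-yl, so that step gives a rough scale for changes here and no direction. Within the data shown here, with only this evidence, a change of similar modest size is expected in this assay, and its direction is uncertain, with a slight lean toward a higher number. The expected change is a 1.5-fold higher number from compound 2 to compound 3 (0.18 log units; within the scatter). The estimated value for compound 3 is 1500 nM, with an expected range of 500 nM to 5000 nM.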

Compound 3, half-maximal effective concentration: 6760 nM
The estimate for compound 3 lay 4.5-fold (0.65 log units) below the measured number, outside the stated range (above it).
By their numbers in this assay, from the lowest: compound 2; then compound 1; then compound 3.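

In this assay, for the compounds shown here, this position on the triple-bonded carbon now shows movement in both directions: 1-benzofuran-3-yl gives a 6.8-fold higher number from compound 2 to compound 3 (0.83 log units; beyond the scatter) and a 3.3-fold higher number from compound 1 to compound 3 (0.52 log units; beyond the scatter), whereas the only earlier step, a 2.1-fold lower number from compound 1 to compound 2 (0.31 log units; beyond the scatter), ran toward a lower number. Compound 3 therefore has the highest number of the three, so a fused five- and six-membered aromatic pair does not by itself hold the number of compound 2 at this place. From compound 2 to compound 3, the counted differences are one hydrogen-bond donor fewer, the same hydrogen-bond acceptor count, and a six-membered ring of carbon only in place of one with a hetero atom; nothing available explains the shift.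

The change from compound 2 to compound 3 alters the ring atoms and the donor count together, so the compounds shown cannot assign the step to either one. An indol-3-yl group, or a 1-benzofuran-3-yl carrying an amine on its six-membered ring, on the same triple-bonded carbon would help separate these two changes.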